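Chloro in place of hydrogen: expected stability of compound 4

This account rests on a few compounds, and the source may have more. Where it says the series, first, only, none or still open, it means among the compounds named here.

Three compounds share one core and differ only in the group attached to the sulfonyl-bearing aryl ring. Compound 1 `CCCCc1[nH]c(=O)c(S(=O)(=O)c2ccc(-c3ccc(F)cc3)cc2)c(O)c1-c1c(OC)cccc1OC` has "not determined" (no result reported) in an ADME assay on microsomes from liver (Homo sapiens) for metabolic stability, using NADPH, with a stated time of 10 min (a higher number here means that more of the compound is left, a lower number that less of the compound is left), so no number is known for it. Compound 2 `CCCCc1[nH]c(=O)c(S(=O)(=O)c2ccc(-c3cccnc3OC)cc2)c(O)c1-c1c(OC)cccc1OC` gives 72% in this assay, and compound 3 `CCCCc1[nH]c(=O)c(S(=O)(=O)c2ccc(-n3ccccc3=O)cc2)c(O)c1-c1c(OC)cccc1OC` gives 100%. Among the compounds with values here, the one measured step, a number 28 percentage points higher from compound 2 to compound 3 (beyond the scatter), exchanges one aromatic ring for another, so compound 3 stands highest of the two numbers known, with compound 2 lower by an amount beyond the scatter.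

Compound 4 `CCCCc1[nH]c(=O)c(S(=O)(=O)c2ccc(-n3cc(Cl)ccc3=O)cc2)c(O)c1-c1c(OC)cccc1OC` differs from compound 3 by chloro in place of hydrogen on an aromatic carbon. Within the data shown here, no measured step involves a chloro group on this ring, so the step from compound 2 to compound 3 does not bear directly on it; it only shows that this part of the molecule can move the read-out. With compound 3 already at complete recovery, a rise is not possible, and the expectation is a step of a number 5 percentage points lower from compound 3 to compound 4 (within the scatter), within the scatter. Compound 4 is therefore estimated at 95%, in a range from 80% to 100%.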

Compound 4, percent of the compound remaining: 97%
Estimate against measurement, compound 4: 2 percentage points below, and the stated range covers the measured number.
By their numbers in this assay, from the lowest: compound 2; then compounds 4 and 3 (each within the scatter of the next).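

In this assay, chloro in place of hydrogen on an aromatic carbon of the six-membered aromatic ring with 1 nitrogen, two atoms from the ring nitrogen, comes with a number 3 percentage points lower from compound 3 to compound 4 (within the scatter), so this position carries a chlorine atom without a step that this read-out can tell from scatter. The chloro-bearing ring also stands apart from the aromatic ring of compound 2, with a number 25 percentage points higher from compound 2 to compound 4 (beyond the scatter), so the separation seen earlier for compound 3 is also found with chloro on the ring. Nothing shown here offers an explanation for this result.

On these data alone, it remains open whether a methyl group, a methoxy group, an amine or a carboxylic acid on this same carbon would also stay within the scatter of compound 3, and whether chloro on another carbon of this ring would do so. The compounds shown also leave open what a longer chain in place of the butyl chain on the shared core would do in this assay.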